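Oxazoline-to-thiazoline swap on the sulfonyl-bound chain, aryl pair changed

This account rests on a few compounds, and the source may have more. Where it says the series, first, only, none or still open, it means among the compounds named here.

Compound 2 `COc1ccc(C2=NOC(c3ccc(C)cc3)C2S(=O)(=O)CC2=NCCO2)cc1` and compound 3 `COc1ccc(C2=NOC(c3ccc(C)cc3)C2S(=O)(=O)CC2=NCCS2)cc1` share a core and differ only in the ring on the saturated chain carbon bound to the sulfonyl sulfur: a group of 5 heavy atoms (3 carbon, 1 nitrogen, 1 sulfur; one five-membered non-aromatic ring with 2 hetero atoms) in place of a group of 5 heavy atoms (3 carbon, 1 nitrogen, 1 oxygen; one five-membered non-aromatic ring with 2 hetero atoms), on a saturated chain carbon bound to a sulfonyl sulfur. In a functional assay, tested at 100 ug/mL (on this read-out lower numbers stand for a weaker effect and higher numbers for a stronger effect at the one concentration tested), compound 2 gives 70.9% and compound 3 gives 52.6%; the step is a number 18.3 percentage points lower from compound 2 to compound 3 (beyond the scatter). Compound 1 `O=S(=O)(CC1=NCCO1)C1C(c2ccc(Cl)cc2)=NOC1c1ccc(Cl)cc1` carries a different aryl pair on the same core; the difference between the two cores is not broken down here. In this assay compound 1 gives "not active" (no number reported). Compound 4 `O=S(=O)(CC1=NCCS1)C1C(c2ccc(Cl)cc2)=NOC1c1ccc(Cl)cc1`, not yet measured, arises from compound 1 by the same change, (a group of 5 heavy atoms (3 carbon, 1 nitrogen, 1 sulfur; one five-membered non-aromatic ring with 2 hetero atoms) in place of a group of 5 heavy atoms (3 carbon, 1 nitrogen, 1 oxygen; one five-membered non-aromatic ring with 2 hetero atoms), on a saturated chain carbon bound to a sulfonyl sulfur), at the same place. Because compound 1 gives "not active" (no number reported) and the same change lowered the read-out in a number 18.3 percentage points lower from compound 2 to compound 3 (beyond the scatter), compound 4 is expected to remain weak in this assay, estimated near 5%, between 0% and 25%.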

Compound 4, a percentage reported as activity, at one concentration (the size of the read-out at that concentration, not a potency): "not active" (no number reported)
Compound 4 has no reported number here; the estimate stays without a comparison.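

In this assay compound 1 gives "not active" (no number reported) and compound 4 gives "not active" (no number reported) and no new step can be read from this pair. The compounds shown leave open whether this ring change, on a saturated chain carbon bound to a sulfonyl sulfur, alters the read-out on the core of compound 1. No evidence bears on this result.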